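The compounds below may be only part of what the source reports. "The series", "measured", "known", "first", "only" and "open" are said of these compounds alone.

Compound 2, with the structure `CN(C)c1nc2cc(Cl)c(Cl)cc2n1COCCO`, is known in a functional assay on KB cells (Homo sapiens) for inhibition (a lower number here means a stronger inhibitor, a higher number a weaker inhibitor), only by a limit: in this assay compound 2 gives > 100000 nM. Among the compounds with values here, compound 1, with the structure `OCCOCn1c(Cl)nc2cc(Cl)c(Cl)cc21`, is the one neighbour measured so far, and in this assay compound 1 also gives only a limit, > 320000 nM. The step from compound 1 to compound 2, a change of dimethylamino in place of chloro on an aromatic carbon, therefore cannot be read, since a step that the two limits leave unreadable from compound 1 to compound 2; the evidence for this sits at the limit of > 100000 nM in this assay, at which 1 of the 2 values shown sits, and at the limit of > 320000 nM in this assay, at which 1 of the 2 values shown sits.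

The next compound is compound 3, with the structure `OCCOCn1c(S)nc2cc(Cl)c(Cl)cc21`. Its change from compound 2 is sulfanyl in place of dimethylamino on an aromatic carbon. Within the data shown here, no measured step runs between numbers that would show how large such a change is, so the step from compound 2 to compound 3 in this assay can only be expected to stay at the edge of what the assay can report, with no readable direction: the estimated step is a step that the limit leaves unreadable from compound 2 to compound 3. On that basis compound 3 is expected to give about 200000 nM in this assay, within a range from 50000 nM to 1000000 nM.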

Compound 3, half-maximal inhibitory concentration: > 100000 nM
Compound 3 ended at the assay's limit; the forecaster's own chance of this, stated with the estimate: 85%; the middle value does not contradict the limit.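

In this assay compound 1, compound 2 and compound 3 are each known only by a limit, and no step among these three compounds can be read. Going by these compounds, whether chloro, dimethylamino or sulfanyl on this aromatic carbon gives the stronger inhibitor in this assay, and by how much, stays open.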